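The source may hold more compounds than are shown below. What is called first, only, known or untested is meant among the compounds shown, and "the series" means these compounds.

Compound 1 `O=C1O[C@H]([C@@H](O)Cn2cc(-c3ccc(Br)cc3)nn2)C(OCc2ccccc2)=C1OCc1ccccc1` gives 5620 nM in a functional assay on MCF7 cells (Homo sapiens) for antiproliferative activity, read by MTT assay, with a stated time of 72 h; a higher number here means a weaker inhibitor, a lower number a stronger inhibitor. Compound 2 `O=C1O/C(=C\Cn2cc(-c3cc(F)cc(F)c3)nn2)C(OCc2ccccc2)=C1OCc1ccccc1` reaches only a limit of this assay, > 100000 nM. Compound 3 `CCCCc1cn(C[C@H](O)[C@H]2OC(=O)C(OCc3ccccc3)=C2OCc2ccccc2)nn1` gives 7910 nM.

Among the two numbers, compound 3 stands highest; its nearest neighbour is compound 1, and the step of a 1.4-fold higher number from compound 1 to compound 3 (0.15 log units; within the scatter) lies within the scatter. Compound 4 `O=C1O[C@H]([C@@H](O)Cn2cc(CNS(=O)(=O)c3ccc(F)cc3)nn2)C(OCc2ccccc2)=C1OCc1ccccc1` differs from compound 3 in one place: ((4-fluorophenyl)sulfonyl)amino in place of propyl on a saturated chain carbon bound to an aromatic carbon. Within the data shown here, the only measured step at a related position is a 1.4-fold higher number from compound 1 to compound 3 (0.15 log units; within the scatter), and it did not move the number beyond the scatter. On that basis compound 4 is expected to change little, a 1.1-fold higher number from compound 3 to compound 4 (0.06 log units; within the scatter), though the entering group is larger than anything measured here. Compound 4 is therefore estimated at 9000 nM, between 2500 nM and 35000 nM.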

Compound 4, half-maximal inhibitory concentration: 26800 nM
For compound 4 the middle estimate is 3.0-fold (0.47 log units) below the measured one; the range from low to high includes it.
By their numbers in this assay, from the lowest: compounds 1 and 3 (each within the scatter of the next); then compound 4. At a limit, above all of these: compound 2.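

Among these compounds, at the position on a saturated chain carbon bound to an aromatic carbon, ((4-fluorophenyl)sulfonyl)amino gives the first change in this assay that goes beyond the scatter, with a 3.4-fold higher number from compound 3 to compound 4 (0.53 log units; beyond the scatter). Against the 4-bromophenyl group, the cut one bond further out gives a 4.8-fold higher number from compound 1 to compound 4 (0.68 log units; beyond the scatter), so this place is not indifferent to what it carries, although butyl and 4-bromophenyl could not be told apart. Nothing measured here accounts for the rise. Going by these compounds, whether the sulfonyl, the amide hydrogen or the fluorine carries the change stays open, as does how an amine or a carboxylic acid would read in this place.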